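Two measured compounds, a third still to come

A few compounds are considered here, and "the series" means these few. Any claim that something is new, unique, unknown or untested is made for them only; others in the source may bear on it.

Compound 1 `COc1ccccc1C1SCC(=O)N1CCN1CCCCC1` and compound 2 `O=C1CSC(c2ccc(F)cc2)N1CCN1CCCCC1` share one core and differ only in the group attached to it. In an ADME assay on Vero cells (Chlorocebus sabaeus) for cytotoxicity, read by neutral red uptake, tested at 787 ug/mL (on this read-out higher numbers stand for a weaker effect at the one concentration tested and lower numbers for a stronger effect), compound 1 gives 30%, while compound 2 gives 17%, the lower of the two numbers, a gap beyond the usual scatter. Compound 3 `O=C1CSC(c2ccccc2Cl)N1CCN1CCCCC1` differs from compound 2 by 2-chlorophenyl in place of 4-fluorophenyl on a saturated ring carbon. Among the compounds with values here, no step between two measured compounds matches this change, so in this assay only a modest step is expected, if any beyond the scatter, leaning slightly upward. Compound 3 is therefore estimated at 24%, within a range from 10% to 42%, which means an expected a number 7 percentage points higher from compound 2 to compound 3 (within the scatter).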

Compound 3, a percentage reported as activity, at one concentration (the size of the read-out at that concentration, not a potency): 38%
Compound 3: middle estimate off by 14 percentage points, on the low side; low and high end bracket the measured number.
By their numbers in this assay, from the lowest: compound 2; then compounds 1 and 3 (each within the scatter of the next).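

In this assay, 2-chlorophenyl in place of 4-fluorophenyl on this saturated ring carbon gives a number 21 percentage points higher from compound 2 to compound 3 (beyond the scatter), so the read-out responds to a change in the aryl group at this position. Chloro in place of methoxy on an aromatic carbon gives a number 8 percentage points higher from compound 1 to compound 3 (within the scatter), so that change cannot be told apart from no change. No measurement shown accounts for either step.

The compounds shown leave open whether the first step follows the halogen or its place on the phenyl ring, which a 4-chlorophenyl group would help separate. Going by these compounds, how an amine or a carboxylic acid on that ring would read also remains open.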